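Methoxy on the Anilino Ring: Expected Effect in the Series

The source may hold more compounds than are shown below. What is called first, only, known or untested is meant among the compounds shown, and "the series" means these compounds.

Measured so far:
compound 1 `Cc1nc(SCC(=O)Nc2nc(-c3ccc(Cl)cc3)cs2)n(Nc2ccccc2)c1C` — 3930 nM
compound 2 `Cc1ccc(Nn2c(SCC(=O)Nc3nc(-c4ccccc4)cs3)nc(C)c2C)cc1` — 1860 nM

In a functional assay on CAKI-1 cells (Homo sapiens) for antiproliferative activity, read by sulforhodamine B assay, with a stated time of 48 h (on this read-out lower numbers stand for stronger inhibition of growth and higher numbers for weaker inhibition of growth), compound 1 gives 3930 nM, the highest of the two numbers. Compound 2 gives 1860 nM, a lower number that lies beyond the scatter; compound 2 differs from compound 1 at two places, so no single structural step can be read from this pair.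

Compound 3 `COc1ccc(Nn2c(SCC(=O)Nc3nc(-c4ccc(Cl)cc4)cs3)nc(C)c2C)cc1` is compound 1 with one change: methoxy in place of hydrogen on an aromatic carbon, para to a large group. For the measured compounds named here, no measured pair isolates this change, and compound 2 carries a different substituent on that ring together with a second difference elsewhere, so it gives only a loose hint.

For compound 3 a step of a 1.5-fold lower number from compound 1 to compound 3 (0.18 log units; within the scatter) is expected, toward a slightly lower number, hardly beyond the scatter. Compound 3 is estimated at 2600 nM, with a range from 1000 nM to 7000 nM.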

Compound 3, concentration for 50% growth inhibition: 2160 nM
Compound 3: middle estimate off by 1.2-fold (0.08 log units), on the high side, and the stated range covers the measured number.
By their numbers in this assay, from the lowest: compounds 2, 3 and 1 (each within the scatter of the next, the first and the last beyond it).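

In this assay, for the compounds shown here, the phenyl to 4-methoxyphenyl change gives a 1.8-fold lower number from compound 1 to compound 3 (0.26 log units; within the scatter), the first step that isolates this position on the anilino ring. Methoxy in place of hydrogen at this position is therefore a change that this read-out does not separate from the usual scatter, so no direction can be assigned to it. Nothing available explains the size of this step or ties it to a property of the methoxy group.

As far as these compounds go, whether an amine, a carboxylic acid or a longer alkoxy chain in the same place would move the number beyond the scatter remains open. Also open, from the compounds shown here alone, is whether methoxy gives a similar step when the rest of the molecule differs from compound 1.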